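The source may hold more compounds than are shown below. What is called first, only, known or untested is meant among the compounds shown, and "the series" means these compounds.

Compound 1, `Nc1cc(N)c2nc(-c3ccccc3)c(Oc3ccc(Cl)c(Cl)c3)nc2c1`, was tested in a functional assay on PC-3 cells (Homo sapiens) for inhibition, read by sulforhodamine B assay, with a stated time of 48 h (on this read-out higher numbers stand for weaker inhibition of growth and lower numbers for stronger inhibition of growth), where compound 1 gives 3020 nM. Compound 3, `CCOC(=O)[C@H](CCC(=O)O)NC(=O)c1ccc(Oc2nc3cc(N)cc(N)c3nc2-c2ccccc2)cc1`, carries an aryl ether on the same core, and in this assay compound 3 gives 2190 nM, a number that lies within the usual scatter of the value for compound 1, so the two cannot be ordered. Compound 2, `CCOC(=O)[C@H](CCC(=O)O)NC(=O)c1ccc(CNc2nc3cc(N)cc(N)c3nc2-c2ccccc2)cc1`, is the third member of the set, and in this assay compound 2 reaches only a limit, < 100000 nM, which is the limit of < 100000 nM in this assay, at which 1 of the 3 values shown sits. Compound 2 and compound 3 share the same acid-bearing tail and differ in the link to the core; their two values show that the ether-linked compound 3 yields a number while the benzylamine-linked compound 2 yields none.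

Compound 4, `Nc1cc(N)c2nc(-c3ccccc3)c(NCc3ccc(F)cc3)nc2c1`, differs from compound 1 by (4-fluorobenzyl)amino in place of 3,4-dichlorophenoxy on an aromatic carbon. Within the data shown here, no measured pair follows exactly this move, so the step is estimated from what the set shows: compound 2, the one benzylamine-linked compound, sits at a limit, < 100000 nM, whereas the ether-linked compound 1 and compound 3 both give numbers. Compound 4 is therefore expected to move toward weaker inhibition, with a step of a 5.0-fold higher number from compound 1 to compound 4 (0.70 log units; beyond the scatter). The estimate for compound 4 in this assay is 15000 nM, with a range from 3000 nM to 70000 nM.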

Compound 4, concentration for 50% growth inhibition: 3470 nM
The estimate for compound 4 lay 4.3-fold (0.64 log units) above the measured number; the range from low to high includes it.
By their numbers in this assay, from the lowest: compounds 3, 1 and 4 (each within the scatter of the next).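

In this assay, the step at this position, on the aromatic carbon next to the ring nitrogen and ortho to a phenyl group, is a 1.1-fold higher number from compound 1 to compound 4 (0.06 log units; within the scatter), so the two compounds cannot be told apart. This first step between compounds differing in one place shows that, on this core, a number in this range does not depend on the ether link: (4-fluorobenzyl)amino, which brings 1 hydrogen-bond donor where 3,4-dichlorophenoxy has 0, serves as well as the group it replaces. Compound 2 remains the only compound at a limit, which is not a number: the limit of < 100000 nM in this assay, at which 1 of the 4 values shown sits.

The single step changes the linking atoms and the halogens on the outer ring together, so the compounds shown do not separate what each contributes, and a version with only the link or only the halogen changed would be needed to do so. Going by these compounds, it also remains open how this position responds to a group of another kind, such as a morpholine, a carboxylic acid or a longer chain like 2-phenylethylamino.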